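From fluoro to bromo on an aromatic carbon

The source may report more compounds than this note shows. Statements on the series, on what has been measured and on what is new or still open speak of the compounds shown alone.

Values so far in a physicochemical assay for lipophilicity, read by mass spectrometry; a higher number here means a more lipophilic compound, a lower number a more polar compound
- compound 1 `COc1ccccc1NC(=O)C1Cc2cc(OC)c(OC)cc2C1=O` gives 2.08
- compound 2 `COc1cc2c(cc1OC)C(=O)C(C(=O)Nc1ccccc1F)C2` gives 2.36

On these numbers compound 2 lies within the scatter of compound 1, so neither stands apart from the other. The change to compound 3 `COc1cc2c(cc1OC)C(=O)C(C(=O)Nc1ccccc1Br)C2` is bromo in place of fluoro on an aromatic carbon and reads, in words, bromo in place of fluoro on an aromatic carbon, ortho to a large group. Among the compounds with values here, one measured step bears on it, and only in part: a number 0.28 log units higher from compound 1 to compound 2 (within the scatter) is the step for fluoro in place of methoxy on an aromatic carbon. Within the data shown here, that step shares the fluoro but says nothing of bromo, and no measured compound carries bromo. The data therefore give no direct size for this change, and what follows is a judgement. Starting from compound 2 at 2.36 in this assay a rise beyond the scatter is expected. The estimated step is a number 0.59 log units higher from compound 2 to compound 3 (beyond the scatter) on this reading. Compound 3 is expected at 2.95 in this assay with a range from 2.6 to 3.3 around that estimate.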

Compound 3, partition coefficient: 3.03
Beside the measured number, compound 3's estimate is 0.08 log units below it; measured number inside the range.
By their numbers in this assay, from the lowest: compounds 1 and 2 (each within the scatter of the next); then compound 3.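

In this assay, within the data shown here, bromo in place of fluoro on an aromatic carbon, ortho to a large group, gives the first step at this position that clears the scatter (a number 0.67 log units higher from compound 2 to compound 3 (beyond the scatter)). Bromo in place of methoxy at the same place also clears it (a number 0.95 log units higher from compound 1 to compound 3 (beyond the scatter)), whereas the step from methoxy to fluoro did not, so the three groups do not fall into an even series: compound 3 stands apart from both of the others, while those two remain within the scatter of each other. Among these compounds, no measurement in hand accounts for the size of either step, and the numbers record only that the change in this one atom is enough to separate compound 3.

The compounds shown leave open where chloro or iodo would fall relative to fluoro and bromo at this place, and whether an amine or a carboxylic acid there would move the number in the opposite direction. They also leave open whether the step from fluoro to bromo keeps its size at another carbon of the same aromatic ring or on a different core.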